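A longer hydroxycarbamoyl chain and the expected gain

The source may report more compounds than this note shows. Statements on the series, on what has been measured and on what is new or still open speak of the compounds shown alone.

Compound 3 `Nc1ncnc2c1c(-c1cnc3[nH]ccc3c1)nn2CCCCCC(=O)NO` ends its chain in a hydroxycarbamoyl group. In a functional assay on HCT-116 cells (Homo sapiens) for inhibition, read by MTT assay, with a stated time of 72 h (on this read-out lower numbers stand for stronger inhibition and higher numbers for weaker inhibition), compound 3 gives 63700 nM, the highest of the two numbers shown; compound 2 `Nc1ncnc2c1c(-c1cnc3[nH]ccc3c1)nn2CCCCCCC(=O)NO` gives 9860 nM. Compound 1 `Nc1ncnc2c1c(-c1cnc3[nH]ccc3c1)nn2CCCC(=O)NO` reaches only a limit of the assay, > 150000 nM. Compound 4 `Nc1ncnc2c1c(-c1cnc3[nH]ccc3c1)nn2CCCCCCCCC(=O)NO` differs from compound 3 in that (3-(hydroxycarbamoyl)propyl in place of hydroxycarbamoyl on a saturated chain carbon, five bonds along the chain from an aromatic nitrogen). The same change placed nearer the aromatic nitrogen gave an at least 15-fold lower number from compound 1 to compound 2 (1.18 log units; beyond the scatter), and shortening the chain by one carbon gave a 6.5-fold higher number from compound 2 to compound 3 (0.81 log units; beyond the scatter), so within these three compounds a longer chain has meant a lower number. A clearly lower number is therefore expected for compound 4, around 2500 nM, within a range of 500 nM to 15000 nM. That expectation amounts to a 25-fold lower number from compound 3 to compound 4 (1.41 log units; beyond the scatter).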

Compound 4, half-maximal inhibitory concentration: 5460 nM
For compound 4 the middle estimate is 2.2-fold (0.34 log units) below the measured one; the measured number falls inside the stated range.
By their numbers in this assay, from the lowest: compounds 4 and 2 (each within the scatter of the next); then compound 3. At a limit, above all of these: compound 1.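

In this assay, the change from hydroxycarbamoyl to 3-(hydroxycarbamoyl)propyl, five bonds along the chain from an aromatic nitrogen, gives a 12-fold lower number from compound 3 to compound 4 (1.07 log units; beyond the scatter), so it still counts at this place. Yet the step between the two longest chains gives a 1.8-fold lower number from compound 2 to compound 4 (0.26 log units; within the scatter), so the steady gain with length seen so far no longer shows. Measured against a value that is only a limit of the assay, the whole lengthening gives an at least 27-fold lower number from compound 1 to compound 4 (1.43 log units; beyond the scatter).

On these data alone, whether a longer chain would hold this level or lose it remains open. So does whether a carboxylic acid could replace the hydroxycarbamoyl end.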